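Swapping a hydroxyl chain for a carboxylic acid

A few compounds are considered here, and "the series" means these few. Any claim that something is new, unique, unknown or untested is made for them only; others in the source may bear on it.

Three coumarin-type amides have been measured in an assay on HEK293 cells for displacement of a labelled ligand from adenosine receptor A2b (Homo sapiens), read by scintillation counting, with a stated time of 30 min, tested at 10 uM; a higher number here means more inhibition at the concentration tested (going by the name of the read-out), a lower number less inhibition. Compound 1 `COc1cccc2cc(C(=O)NCC(=O)O)c(=O)oc12` gives 35%, compound 2 `O=C(NC1CCCC1)c1cc2ccccc2oc1=O` gives 18%, and compound 3 `O=C(NCCCO)c1cc2ccccc2oc1=O` gives 19%. Compound 3 thus stands second highest of the three, its nearest neighbour being compound 2, whose number is within the scatter of it, while compound 1 lies beyond the scatter above it. Within the data shown here, the only measured step, a number 1 percentage points higher from compound 2 to compound 3 (within the scatter), concerns a different change at the amide nitrogen and stays within the scatter, so it says little about what follows.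

Compound 4 `O=C(O)CNC(=O)c1cc2ccccc2oc1=O` has not yet been measured. It differs from compound 3 in one place: carboxy in place of 2-hydroxyethyl on a saturated chain carbon bound to an amide-type nitrogen. Compound 1 carries the same carboxymethyl group on its amide nitrogen but also bears an extra group on the shared core, so its value can only hint at where compound 4 may fall. On that hint, compound 4 is expected to give 26%, with a range of 10% to 42%, in this assay. This would mean an estimated step of a number 7 percentage points higher from compound 3 to compound 4 (within the scatter), expected to be upward but modest.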

Compound 4, a percentage reported as inhibition, at one concentration (the size of the read-out at that concentration, not a potency): 9%
For compound 4 the middle estimate is 17 percentage points above the measured one; the whole stated range lies above it.
By their numbers in this assay, from the lowest: compounds 4, 2 and 3 (each within the scatter of the next); then compound 1.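

At this place on the amide side chain, carboxy in place of 2-hydroxyethyl gives a number 10 percentage points lower from compound 3 to compound 4 (within the scatter), and carboxymethyl in place of cyclopentyl gives a number 9 percentage points lower from compound 2 to compound 4 (within the scatter), so in this assay neither change separates compound 4 from its neighbours. The one clear difference comes from elsewhere: hydrogen in place of methoxy on an aromatic carbon gives a number 26 percentage points lower from compound 1 to compound 4 (beyond the scatter), which shows that the carboxymethyl amide alone does not carry the higher number of compound 1 and that the methoxy group on the core makes a difference in this pair. No measurement here explains why these numbers fall as they do.

From the compounds shown here alone, it remains open whether methoxy on the same aromatic carbon would make a similar difference with cyclopentyl or 3-hydroxypropyl on the amide nitrogen. An amine or a longer chain ending in a carboxylic acid at this place also remains to be placed in this series.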